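A Chlorine Added to the Alkyne Phenyl Ring

The source may hold more compounds than are shown below. What is called first, only, known or untested is meant among the compounds shown, and "the series" means these compounds.

Compound 1 `O=C(NC1CCCC1)c1ccc(C#Cc2ccccc2)nc1` carries a phenyl ring on its triple-bonded carbon. In a functional assay on HEK293 cells for positive allosteric modulation of metabotropic glutamate receptor 5 (Homo sapiens), read by FLIPR and calcium flux (a higher number here means that more compound is needed for the effect, a lower number that less compound is needed), compound 1 gives 19 nM. Compound 2 `O=C(NC1CCCC1)c1ccc(C#Cc2cccnc2)nc1` has pyridin-3-yl in that place instead. In this assay compound 2 gives > 10000 nM, which is a limit and not a number. Compound 2 thus sits at the limit of > 10000 nM in this assay, at which 1 of the 3 values shown sits. That ring swap gives an at least 520-fold higher number from compound 1 to compound 2 (2.72 log units; beyond the scatter). Compound 3 `O=C1c2ccc(C#Cc3ccccc3)nc2CCN1C1CCCC1` keeps the phenyl alkyne but closes the amide into a ring of the shared core; in this assay compound 3 gives 5.9 nM, the lowest of the two numbers measured, with compound 1 the nearest at a higher number. Compound 4 `O=C1c2ccc(C#Cc3ccc(Cl)cc3)nc2CCN1C1CCCC1` differs from compound 3 by chloro in place of hydrogen on an aromatic carbon, placed on an aromatic carbon of a six-membered aromatic ring of carbon only, para to a large group; cut one bond further out the change reads phenyl to 4-chlorophenyl. Among the measured compounds shown here, the one measured step, from compound 1 to compound 2, changes a ring atom rather than adding a group, so no measured step directly matches this change. The change from compound 3 to compound 4 is expected to give a step of a 1.0-fold higher number from compound 3 to compound 4 (0.01 log units; within the scatter), within the usual scatter. In this assay compound 4 is therefore estimated at 6 nM, between 2 nM and 20 nM.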

Compound 4, half-maximal effective concentration: 979 nM
For compound 4 the middle estimate is 160-fold (2.21 log units) below the measured one, outside the stated range (above it).
By their numbers in this assay, from the lowest: compound 3; then compound 1; then compound 4. At a limit, above all of these: compound 2.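

In this assay, chloro in place of hydrogen on the phenyl ring of the alkyne, para to a large group, gives a 170-fold higher number from compound 3 to compound 4 (2.22 log units; beyond the scatter), so this single change takes the shared core from the lowest number shown to well above the two other measured numbers. Before this, the only large step at this ring was the swap of a ring atom for pyridin-3-yl on the core of compound 1; compound 4 shows that the phenyl ring can stay intact and one added chlorine atom is still enough for a large step. Nothing in the data shown explains this rise.

On these data alone, whether a fluoro or a methoxy group at this place would give a step of similar size remains open. Also open, as far as these compounds go, is whether chloro would give a similar step on the core of compound 1.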